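Swapping Chloro for Methoxy on a Shared Core

The source may hold more compounds than are shown below. What is called first, only, known or untested is meant among the compounds shown, and "the series" means these compounds.

Of the compounds shown here, two built on one shared core have been measured for how large a response they produce. In a functional assay on CHO cells for agonist activity at Alpha-2C adrenergic receptor (Homo sapiens) (a higher number here means a larger maximal response, a lower number a smaller maximal response), compound 2 `CS(=O)(=O)c1ccc(Cl)cc1NCC1=NCCN1` gives 81%. In this assay compound 1 `CS(=O)(=O)c1cc(Cl)ccc1NCC1=NCCN1` gives 54%. Among the compounds with values here, compound 2 therefore stands highest of the two numbers, and its only neighbour, compound 1, lies a long way below it, clearly beyond the usual scatter of repeated measurements.

Compound 3 `COc1ccc(S(C)(=O)=O)c(NCC2=NCCN2)c1` has not yet been measured. Its structure differs from compound 2 in one place: methoxy in place of chloro on an aromatic carbon. Within the data shown here, no measured pair shows a change of this kind, so the two known values give no direct guide to its size or direction. With the chloro group gone and a methoxy group in its place, a moderate drop in the largest response reached seems the more likely outcome, and the expected step is a number 19 percentage points lower from compound 2 to compound 3 (beyond the scatter). Compound 3 is expected to give 62% in this assay, within a range from 35% to 90%.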

Compound 3, largest response reached (reported as maximum), in percent of the reference or control that the assay uses: 49%
For compound 3 the middle estimate is 13 percentage points above the measured one; the measured number falls inside the stated range.
By their numbers in this assay, from the lowest: compounds 3 and 1 (each within the scatter of the next); then compound 2.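

Within the data shown here, this is the first direct view of what the group on this aromatic carbon, para to the methylsulfonyl group, can do: in this assay, methoxy in place of chloro gives a number 32 percentage points lower from compound 2 to compound 3 (beyond the scatter) as a large step. The exchange is small on paper, with a single chlorine atom leaving and a methoxy group of 2 heavy atoms and 1 hydrogen-bond acceptor entering, yet the largest response reached clearly depends on which of these two groups occupies this place. No measurement shown accounts for the fall, so the step stands as an observation without an explanation.

With only chloro and methoxy compared here, the compounds shown leave open whether the response follows any trend across other groups at this position, such as a methyl, a nitrile or an amine. They also leave open whether methoxy in place of chloro on the core of compound 1 would bring a step of similar size and direction, or whether this step belongs to this one position.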